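A few compounds are considered here, and "the series" means these few. Any claim that something is new, unique, unknown or untested is made for them only; others in the source may bear on it.

Compound 1 `COc1ccc(/C=C/c2cc(OC)c(OC)c(OC)c2-c2ccc(OC)cc2)cc1` and compound 2 `COc1ccc(/C=C/c2cc(OC)c(OC)c(OC)c2-c2ccc(OC)c(OC)c2)cc1` share a core that carries a trimethoxylated ring and a double bond, and in a functional assay on DU-145 cells (Homo sapiens) for cytotoxicity, read by MTT assay, with a stated time of 48 h (on this read-out lower numbers stand for stronger inhibition and higher numbers for weaker inhibition), compound 1 gives 34000 nM, while compound 2 gives 34000 nM. The change from compound 2 to compound 1 is hydrogen in place of methoxy on an aromatic carbon, and no change at the digits printed from compound 2 to compound 1 (within the scatter).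

Compound 3 `C=C(c1ccc(OC)cc1)c1cc(OC)c(OC)c(OC)c1-c1ccccc1` is built on a core that differs from that of compound 2 in a way that is not broken down here; in this assay compound 3 gives 8000 nM, the lowest of the three numbers, with each of the other two standing beyond the scatter above it.

Compound 4 `C=C(c1ccccc1)c1cc(OC)c(OC)c(OC)c1-c1ccccc1` is not yet measured. It differs from compound 3 by hydrogen in place of methoxy on an aromatic carbon. For the measured compounds named here, this is the same kind of change as the one from compound 2 to compound 1, but not the same: there the leaving methoxy sat ortho to a methoxy group and meta to a large group, here it sits para to a large group. Because the measured step was no change at the digits printed from compound 2 to compound 1 (within the scatter), only a small shift is expected, so the step from compound 3 to compound 4 is estimated at a 1.8-fold higher number from compound 3 to compound 4 (0.24 log units; within the scatter). Compound 4 is expected to give about 14000 nM, between 5000 nM and 40000 nM.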

Compound 4, half-maximal inhibitory concentration: 36000 nM
Compound 4: middle estimate off by 2.6-fold (0.41 log units), on the low side; measured number inside the range.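

Replacing a methoxy group with hydrogen, here 4-methoxyphenyl to phenyl, gives a 4.5-fold higher number from compound 3 to compound 4 (0.65 log units; beyond the scatter) in this assay. Set beside the earlier step, the same change does not give the same result on the two cores: the same change on two cores in this assay, no change at the digits printed (within the scatter) from compound 2 to compound 1 and a 4.5-fold higher number (0.65 log units; beyond the scatter) from compound 3 to compound 4, 4.5-fold (0.65 log units) apart, beyond the scatter of two such steps. So the size of this step on one core cannot simply be carried over to another core in this series, but two pairs of compounds do not show what sets the cores apart, nor how large the step would be on a third core.

The compounds shown leave open how other groups would compare with methoxy and hydrogen on this aromatic carbon, for instance a hydroxyl, an amine or a carboxylic acid. They also leave open whether the gap between the two steps would hold in cells other than those tested here.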